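The source may hold more compounds than are shown below. What is called first, only, known or untested is meant among the compounds shown, and "the series" means these compounds.

Among the measured compounds shown here, in a functional assay on K562 cells (Homo sapiens), read by MTT assay, with a stated time of 72 h (a higher number here means a weaker inhibitor, a lower number a stronger inhibitor), none of the three compounds measured so far gives a number. Compound 1 `CSc1ncnc2c1c(-c1ccccc1)cn2[C@@H]1O[C@H](CO)[C@@H](O)[C@H]1O` reads > 20000 nM, which is a limit of the assay and not a measured value. Compound 2 `Nc1nc(N)c2c(-c3ccco3)cn([C@@H]3O[C@H](CO)[C@@H](O)[C@H]3O)c2n1` reads > 20000 nM, again a limit. Compound 3 `Cc1nc(N)c2c(-c3ccco3)cn([C@@H]3O[C@H](CO)[C@@H](O)[C@H]3O)c2n1` reads > 20000 nM, also a limit. Compound 3 therefore stands with the other two, at the limit of > 20000 nM in this assay, at which 3 of the 3 values shown sit.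

Compound 4 `C#Cc1cn([C@@H]2O[C@H](CO)[C@@H](O)[C@H]2O)c2nc(C)nc(N)c12` differs from compound 3 in one group, with ethynyl in place of furan-2-yl on an aromatic carbon. For the measured compounds named here, the only measured step is a step that the two limits leave unreadable from compound 2 to compound 3. Going by the values given here, it swaps a different group and gives no size to carry forward, so no measured step shows what the new swap does.

The expectation is therefore loose. Compound 3 offers only the limit of > 20000 nM as a starting point, so compound 4 may well stop at the same limit in this assay. If it gives a number, a lower one, meaning a stronger inhibitor, is the only kind that could be read. The expected change is an at least 2.5-fold lower number from compound 3 to compound 4 (0.39 log units; beyond the scatter), a rough estimate. For compound 4 the estimated value is 8000 nM, with an expected range from 1000 nM to 20000 nM.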

Compound 4, half-maximal inhibitory concentration: 3290 nM
For compound 4 the middle estimate is 2.4-fold (0.39 log units) above the measured one, within the range that was stated.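

In this assay, among the compounds shown here, ethynyl in place of furan-2-yl on this aromatic carbon gives an at least 6.0-fold lower number from compound 3 to compound 4 (0.78 log units; beyond the scatter), the first sign that a change at this position can move the read-out. Compound 3 has only a limit, so this step gives a minimum size and not an exact one. The change replaces a five-membered aromatic ring of 5 heavy atoms with a ring-free group of 2 heavy atoms containing a triple bond, and compound 4 alone gives a number, while the other compounds remain at the limit: the limit of > 20000 nM in this assay, at which 3 of the 4 values shown sit.

Going by these compounds, this single swap cannot separate the loss of the ring from the smaller size or the arrival of the triple bond, so it remains open whether an ethyl group or a nitrile on this carbon would give a similar number. For the compounds shown here, the only earlier step, from amino to methyl, cannot be read, so what those two groups do when ethynyl is present also remains open.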